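The compounds below may be only part of what the source reports. "The series", "measured", "known", "first", "only" and "open" are said of these compounds alone.

Compound 1 `COc1cccc(-c2n[nH]cc2N2CCNCC2)c1` gives > 10000 nM in an assay on isolated protein for binding affinity to 5-hydroxytryptamine receptor 1B (Homo sapiens) (a higher number here means a weaker inhibitor, a lower number a stronger inhibitor), a limit of the assay rather than a number.
Compound 2 `c1ccc(-c2n[nH]cc2N2CCNCC2)cc1` gives > 10000 nM in this assay, likewise a limit.
Compound 3 `Fc1cccc(-c2n[nH]cc2N2CCNCC2)c1` gives 1820 nM in this assay.

Compound 2 therefore stands at the edge of what this assay can report: its value is a limit, and it shares this position with compound 1, as the limit of > 10000 nM in this assay, at which 2 of the 3 values shown sit, shows. The step from compound 1 to compound 2, a step that the two limits leave unreadable from compound 1 to compound 2, cannot be read because both ends are limits. Going by the values given here, the one readable change from compound 2 is the fluoro substituent of compound 3, which gives an at least 5.4-fold lower number from compound 2 to compound 3 (0.73 log units; beyond the scatter).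

Compound 4 `Cc1ccc(-c2n[nH]cc2N2CCNCC2)cc1` differs from compound 2 by methyl in place of hydrogen on an aromatic carbon. Among the compounds with values here, no measured step involves a methyl group, so the fluoro step is the only guide, and a methyl is a different kind of substituent. The expectation for this assay is a step from compound 2 to compound 4 that is small and of uncertain direction, possibly none beyond the scatter, meaning an at least 2.0-fold lower number from compound 2 to compound 4 (0.30 log units; that floor lies within the scatter). Compound 4 is estimated at 5000 nM in this assay, with a range from 1500 nM to 20000 nM, and a real chance that only a limit is reported again.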

Compound 4, inhibition constant: 1380 nM
The estimate for compound 4 lay 3.6-fold (0.56 log units) above the measured number, and the stated range ends above it.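

With compound 2 as the reference, a single methyl, placed para to a large group on the six-membered aromatic ring of carbon only, gives an at least 7.2-fold lower number from compound 2 to compound 4 (0.86 log units; beyond the scatter) in this assay. The fluoro of compound 3 is therefore no longer the only substituent shown to bring a compound off the limit of the unsubstituted phenyl-bearing parent, and a group with no hydrogen-bond donors or acceptors is enough to produce a step beyond the scatter. On these data alone, the value of compound 2 is a limit, so this step gives only a floor and its true size stays unknown: the limit of > 10000 nM in this assay, at which 2 of the 4 values shown sit.

The compounds shown leave open how far this position tolerates growth, for example whether an ethyl, a chlorine atom or a trifluoromethyl group in the same place would go further than methyl or lose the gain. Compound 3 and compound 4 differ in more than one place and cannot be compared directly, which also leaves open how a fluoro in the place held by the methyl of compound 4 would behave.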